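The compounds below may be only part of what the source reports. "The series", "measured", "known", "first", "only" and "open" are said of these compounds alone.

Measured so far in a functional assay on DU-145 cells (Homo sapiens) for inhibition, read by sulforhodamine B assay, with a stated time of 48 h, tested at 10 uM; on this read-out lower numbers stand for a stronger effect and higher numbers for a weaker effect at the one concentration tested:

compound 1 `O=C(Nc1cccc(-n2cc(-c3ccncc3)c(-c3cc(O)cc(Cl)c3)n2)c1)Nc1ccc(Cl)c(C(F)(F)F)c1` gives 18.7%
compound 2 `COc1cc(Cl)cc(-c2nn(-c3cccc(NC(=O)Nc4ccc(Cl)c(C(F)(F)F)c4)c3)cc2-c2ccncc2)c1` gives 15.2%
compound 3 `O=C(Nc1cccc(-n2cc(-c3ccncc3)c(-c3cc(O)cc(Cl)c3)n2)c1)c1cc(C(F)(F)F)cc(C(F)(F)F)c1` gives 62.1%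

Compound 1 and compound 2 share one core and differ by methyl in place of hydrogen on an oxygen on an aromatic ring. That change gave a number 3.5 percentage points lower from compound 1 to compound 2 (within the scatter), so the two compounds cannot be told apart on this read-out. Compound 3 stands highest of the three; its gap to compound 1 and its gap to compound 2 both lie beyond the scatter. The difference between the core of compound 3 and the core of compound 1 is not broken down here.

Compound 4 `COc1cc(Cl)cc(-c2nn(-c3cccc(NC(=O)c4cc(C(F)(F)F)cc(C(F)(F)F)c4)c3)cc2-c2ccncc2)c1` has not yet been measured in this assay. It differs from compound 3 by methyl in place of hydrogen on an oxygen on an aromatic ring, which is the same change already seen between compound 1 and compound 2, at the same kind of place. Because that earlier step came to a number 3.5 percentage points lower from compound 1 to compound 2 (within the scatter), compound 4 is expected to stay close to compound 3, with an expected step of a number 3.1 percentage points lower from compound 3 to compound 4 (within the scatter). The estimate for compound 4 in this assay is 59%, expected to fall between 44% and 74%.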

Compound 4, a percentage reported as activity, at one concentration (the size of the read-out at that concentration, not a potency): 78.2%
Compound 4: middle estimate off by 19.2 percentage points, on the low side; the whole stated range lies below it.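

In this assay, replacing hydroxy with methoxy on the 3-chloro-5-hydroxyphenyl group gave a number 16.1 percentage points higher from compound 3 to compound 4 (beyond the scatter), a weaker effect at the one concentration tested. The same change therefore did not carry over unchanged from the core of compound 1 to the core of compound 3: the same change on two cores in this assay, a number 3.5 percentage points lower (within the scatter) from compound 1 to compound 2 and a number 16.1 percentage points higher (beyond the scatter) from compound 3 to compound 4, 19.6 percentage points apart, beyond the scatter of two such steps. This shows that, for these two pairs, the step from one core cannot be transferred to the other, but two pairs give no general rule for other cores and do not show which feature of the cores sets the two steps apart.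

The compounds shown leave open whether a different group on that oxygen, such as an ethyl group or a longer chain, would follow the step seen on either core. They also leave open how an amine or a carboxylic acid in place of the hydroxy would read out on each core.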